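A Methoxy-to-Bromo Swap on Two Related Cores

The compounds below may be only part of what the source reports. "The series", "measured", "known", "first", "only" and "open" are said of these compounds alone.

Compound 1 `C=C1C[C@]23C[C@@]1(O)CC[C@@H]2c1cccc(C)c1[C@@H]3Cn1cc(-c2ccc(OC)cc2)nn1` and compound 2 `C=C1C[C@]23C[C@@]1(O)CC[C@@H]2c1cccc(C)c1[C@@H]3Cn1cc(-c2ccc(Br)cc2)nn1` share one core and differ in a single place: bromo in place of methoxy on an aromatic carbon. In a functional assay on A549 cells (Homo sapiens) for cytotoxicity, read by MTT assay, with a stated time of 4 days (a lower number here means a stronger inhibitor, a higher number a weaker inhibitor), compound 1 gives > 20000 nM, which is a limit of the assay and not a number. In this assay compound 2 gives > 20000 nM, again a limit rather than a number. Going by the values given here, the measured step is therefore a step that the two limits leave unreadable from compound 1 to compound 2, and the only evidence bearing on it is the limit of > 20000 nM in this assay, at which 2 of the 3 values shown sit.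

Compound 3 `C=C1C(=O)[C@]23C[C@@]1(O)CC[C@H]2c1ccc(O)c(C)c1[C@@H]3Cn1cc(-c2ccc(OC)cc2)nn1` stands on a different core; the difference between the two cores is not broken down here. In this assay, among the compounds with values here, compound 3 gives 1250 nM, the only number among the three values.

Compound 4 `C=C1C(=O)[C@]23C[C@@]1(O)CC[C@H]2c1ccc(O)c(C)c1[C@@H]3Cn1cc(-c2ccc(Br)cc2)nn1` has not yet been measured. It differs from compound 3 in the same way, (bromo in place of methoxy on an aromatic carbon), the same change that separates compound 1 from compound 2. Because a step that the two limits leave unreadable from compound 1 to compound 2 is unreadable from two limits, no size can be carried over from the earlier pair. The step from compound 3 to compound 4 is therefore expected to be small, a 1.2-fold higher number from compound 3 to compound 4 (0.08 log units; within the scatter), with wide uncertainty on either side. Compound 4 is expected to give about 1500 nM in this assay. For compound 4 the expected range runs from 400 nM to 8000 nM.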

Compound 4, half-maximal inhibitory concentration: 1140 nM
For compound 4 the middle estimate is 1.3-fold (0.12 log units) above the measured one; measured number inside the range.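

In this assay, placing bromo where methoxy stood on the core of compound 3 gives a 1.1-fold lower number from compound 3 to compound 4 (0.04 log units; within the scatter), so on this core the two groups cannot be told apart. The same change on the core of compound 1 cannot be read, and all that bears on it is a limit of the assay, not a number: the limit of > 20000 nM in this assay, at which 2 of the 4 values shown sit. The series therefore offers one readable instance of the change and no comparison between two cores, so it does not show that the step carries from one core to the other, nor that it would hold on any further core.

The compounds shown leave open whether an amine, a carboxylic acid or a nitrile at this same place, para to a large group, would read like methoxy and bromo on the core of compound 3. The difference between the two cores is not broken down among these compounds either, so it remains open which part of the core of compound 3 sets its readable values apart from the limits of the other core.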